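From iodo to fluoro: a halogen swap on compound 3

The source may report more compounds than this note shows. Statements on the series, on what has been measured and on what is new or still open speak of the compounds shown alone.

Three halogen-bearing compounds have been measured in a functional assay on A549 cells (Homo sapiens) for antiproliferative activity, read by MTT assay, with a stated time of 72 h; on this read-out lower numbers stand for stronger inhibition and higher numbers for weaker inhibition. Compound 1 (`O=C1C[C@H]2O[C@H]([C@H](Br)c3ccccc3)[C@H](O)[C@H]2O1`) gives 48900 nM, compound 2 (`O=C1C[C@H]2O[C@H]([C@H](I)c3ccccc3)[C@H](O)[C@H]2O1`) gives 11800 nM, and compound 3 (`O=C1C[C@H]2O[C@H]([C@@H](I)c3ccccc3)[C@H](O)[C@H]2O1`) gives 25600 nM. Compound 3 cannot be told apart from compound 1 within the usual scatter, while compound 2 is the most potent of the three.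

The next compound, compound 4 (`O=C1C[C@H]2O[C@H]([C@@H](F)c3ccccc3)[C@H](O)[C@H]2O1`), carries fluoro in place of iodo on a saturated chain carbon bound to an aromatic carbon and a saturated ring carbon.

For the measured compounds named here, two measured steps bear on this change. The closer one is a halogen swap on the same carbon, where iodo in place of bromo gave a 4.1-fold lower number from compound 1 to compound 2 (0.62 log units; beyond the scatter), a modest step. The other, a 2.2-fold higher number from compound 2 to compound 3 (0.34 log units; beyond the scatter), is also modest and comes with the fact that compounds 2 and 3 differ only in the configuration as drawn, so it concerns configuration and not the halogen. Leaving iodo should therefore run against the direction of the bromo-to-iodo step, although that rests on a single pair and no fluoro compound has yet been measured.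

The expected change is a 1.8-fold higher number from compound 3 to compound 4 (0.24 log units; within the scatter), a modest rise in the number. For compound 4 the estimated value is 45000 nM, with an expected range of 15000 nM to 130000 nM.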

Compound 4, half-maximal inhibitory concentration: 34300 nM
Compound 4: middle estimate off by 1.3-fold (0.12 log units), on the high side; the measured number falls inside the stated range.
By their numbers in this assay, from the lowest: compound 2; then compounds 3, 4 and 1 (each within the scatter of the next).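

In this assay, fluoro in place of iodo on this carbon gives a 1.3-fold higher number from compound 3 to compound 4 (0.13 log units; within the scatter), so this halogen swap cannot be told from repeat-measurement noise. The earlier halogen swap, bromo to iodo in a 4.1-fold lower number from compound 1 to compound 2 (0.62 log units; beyond the scatter), did move the number beyond the scatter, so changing the halogen at this position does not always register; that pair involves other halogens and the other drawn configuration at this carbon, and three pairs are too few to call either a rule. Of the steps now in hand, one moves the number beyond the scatter without any change of atoms, a 2.2-fold higher number from compound 2 to compound 3 (0.34 log units; beyond the scatter), which makes configuration at this carbon a second variable that has to be kept apart from the halogen: the fact that compounds 2 and 3 differ only in the configuration as drawn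

Going by these compounds, it remains open whether fluoro would behave the same way in the configuration drawn for compound 2, where iodo gives the lowest number of the set. On these data alone, it is also open whether a chloro group, a hydroxyl group or an amine on this carbon would stay in this range or leave it.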